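The source may report more compounds than this note shows. Statements on the series, on what has been measured and on what is new or still open speak of the compounds shown alone.

Compound 1 `CN(C)c1ccc(-c2ccc(Cl)cc2)c(COc2ccc(-c3nc4cc(C(=O)O)ccc4n3C3CCCCC3)cc2)c1` gives 30000 nM
Compound 2 `N#Cc1ccc(-c2ccc(Cl)cc2)c(COc2ccc(-c3nc4cc(C(=O)O)ccc4n3C3CCCCC3)cc2)c1` gives 23000 nM

In a functional assay on Huh-5-2 cells (Homo sapiens), read by MTT assay (a higher number here means that more compound is tolerated, a lower number that less compound is tolerated), compound 2 stands at 23000 nM and so lies within the scatter of compound 1. Compound 3 `CN(C)C(=O)c1ccc(-c2ccc(Cl)cc2)c(COc2ccc(-c3nc4cc(C(=O)O)ccc4n3C3CCCCC3)cc2)c1` carries dimethylcarbamoyl in place of cyano on an aromatic carbon. For the measured compounds named here, only one measured step bears on this change: cyano in place of dimethylamino on the same carbon gave a 1.3-fold lower number from compound 1 to compound 2 (0.12 log units; within the scatter) and stayed within the scatter. No step beyond the scatter is therefore expected in this assay, and no direction can be called. The expected step is small (a 1.1-fold higher number from compound 2 to compound 3 (0.04 log units; within the scatter)). For compound 3 the estimated value is 25000 nM (expected range 12000 nM to 50000 nM).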

Compound 3, half-maximal cytotoxic concentration: 28000 nM
Compound 3: the middle estimate sits 1.1-fold (0.05 log units) below what was measured, and the stated range covers the measured number.
By their numbers in this assay, from the lowest: compounds 2, 3 and 1 (each within the scatter of the next).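

In this assay, with dimethylcarbamoyl on this aromatic carbon para to a 4-chlorophenyl group, a 1.2-fold higher number from compound 2 to compound 3 (0.09 log units; within the scatter) and a 1.1-fold lower number from compound 1 to compound 3 (0.03 log units; within the scatter) both lie within the scatter. Dimethylamino, cyano and the larger dimethylcarbamoyl, with its carbonyl, therefore cannot be told apart at this position, so a third group here again produces no step beyond the scatter. Nothing available bears on why this position shows so little response. Going by these compounds, it remains open whether a carboxylic acid or a primary amine on this carbon would produce a step beyond the scatter.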